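Carboxy in place of hydroxy, a second instance

The compounds below may be only part of what the source reports. "The series", "measured", "known", "first", "only" and "open" are said of these compounds alone.

Measured in a functional assay on Hep 3B2 cells (Homo sapiens) for antiproliferative activity, read by MTT assay, with a stated time of 24 h, tested at 33.33 ug/mL; on this read-out higher numbers stand for a stronger effect at the one concentration tested and lower numbers for a weaker effect:
compound 1, `Cc1c(C(=O)Nc2c(F)cc(-c3cccc(F)c3)cc2F)nc2ccc(C(F)(F)F)cc2c1O`: 45.2%
compound 2, `COc1ccc2nc(C(=O)Nc3ccc(-c4ccccc4)cc3)c(C)c(O)c2c1`: 48.4%
compound 3, `Cc1c(C(=O)Nc2c(F)cc(-c3cccc(F)c3)cc2F)nc2ccc(C(F)(F)F)cc2c1C(=O)O`: 43.3%

The three numbers lie within the scatter of one another, so no order among compounds 1, 2 and 3 is claimed. Compound 3 differs from compound 1 by carboxy in place of hydroxy on an aromatic carbon; the step was a number 1.9 percentage points lower from compound 1 to compound 3 (within the scatter). The difference between the cores of compound 1 and compound 2 is not broken down here.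

Compound 4, `COc1ccc2nc(C(=O)Nc3ccc(-c4ccccc4)cc3)c(C)c(C(=O)O)c2c1`, has not been measured. It differs from compound 2 by carboxy in place of hydroxy on an aromatic carbon, the same change as from compound 1 to compound 3, at a place described in the same words. Among the compounds with values here, the only measured instance of this change is the step of a number 1.9 percentage points lower from compound 1 to compound 3 (within the scatter), which stayed within the scatter; on that basis a step of about a number 1.9 percentage points lower from compound 2 to compound 4 (within the scatter) is expected, and compound 4 is estimated at 46.5%, between 35% and 58%.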

Compound 4, a percentage reported as inhibition, at one concentration (the size of the read-out at that concentration, not a potency): 33.6%
The estimate for compound 4 lay 12.9 percentage points above the measured number; the measured number lies below the stated range.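

On the second core, carboxy in place of hydroxy on an aromatic carbon gave a number 14.8 percentage points lower from compound 2 to compound 4 (beyond the scatter) in this assay. Set beside the first instance, the two steps cannot be told apart: the same change on two cores in this assay, a number 1.9 percentage points lower (within the scatter) from compound 1 to compound 3 and a number 14.8 percentage points lower (beyond the scatter) from compound 2 to compound 4, 12.9 percentage points apart, within the scatter of two such steps. This does not show that the core alters the step, nor that the step carries over at a fixed size; two instances at one concentration settle neither reading.

Still open, going by these compounds, is whether an amine or a longer chain in place of hydroxy on this aromatic carbon would read closer to hydroxy or to carboxy. Also open, on these data alone, is how the carboxy for hydroxy step behaves on any core beyond these two.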